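Fluoro for methoxy on a shared core: working notes

A few compounds are considered here, and "the series" means these few. Any claim that something is new, unique, unknown or untested is made for them only; others in the source may bear on it.

Measured so far in a functional assay on HT-29 cells (Homo sapiens) for inhibition, read by sulforhodamine B assay, with a stated time of 48 h; a lower number here means a stronger inhibitor of growth, a higher number a weaker inhibitor of growth:
- compound 1, `CCOC(=O)C1=C(C)NC(=S)NC1c1cc(OC)c(O)c(OC)c1`, gives 28.2 ug/mL
- compound 2, `CCOC(=O)C1=C(C)NC(=O)NC1c1ccc(O)c(O)c1`, gives 37.8 ug/mL
- compound 3, `CCOC(=O)C1=C(C)NC(=S)NC1c1ccc(OC)cc1`, gives 30.6 ug/mL

The three numbers lie close together. Compound 3 stands second highest of the three; its nearest neighbour is compound 1 and its furthest is compound 2, and both gaps fall within the scatter, so no order among the three can be read from this assay.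

Compound 4, `CCOC(=O)C1=C(C)NC(=S)NC1c1ccc(F)cc1`, has not yet been measured. It differs from compound 3 in one place: fluoro in place of methoxy on an aromatic carbon. Among the compounds with values here, no pair of measured compounds shows a step at this position, so the data give no measured size for such a change. With all measured values bunched together, the expected step of a 1.0-fold lower number from compound 3 to compound 4 (0.01 log units; within the scatter) is small, no larger than the scatter, with no direction preferred. Compound 4 is therefore estimated at 30 ug/mL in this assay, with a range from 15 ug/mL to 60 ug/mL.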

Compound 4, concentration for 50% growth inhibition: 26.5 ug/mL
Compound 4: the middle estimate sits 1.1-fold (0.05 log units) above what was measured, within the range that was stated.
By their numbers in this assay, from the lowest: compounds 4, 1, 3 and 2 (each within the scatter of the next).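

In this assay, the exchange of methoxy for fluoro on an aromatic carbon, para to a large group, now has a measured size: a 1.2-fold lower number from compound 3 to compound 4 (0.06 log units; within the scatter). This first step at the position shows that, in this pair, the methoxy group can give way to the smaller fluoro group, which has no hydrogen-bond acceptor under the count used here, with no readable difference in the number. The data offer no measured basis for explaining this result.

The compounds shown leave open whether a primary amine, a carboxylic acid or a longer alkoxy chain at this position would give a step beyond the scatter. They also leave open whether fluoro for methoxy would give a similar step on a core carrying a carbonyl, as in compound 2, rather than the sulfur of compound 3.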